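A Methyl Group Added to a Weak Amine Oxidase Inhibitor

This account rests on a few compounds, and the source may have more. Where it says the series, first, only, none or still open, it means among the compounds named here.

Three compounds built on a shared core have been compared in an assay on isolated protein for inhibition of Amine oxidase [flavin-containing] B (Homo sapiens), read by fluorescence and Amplex Red, with stated times of 15 min and 20 min; a higher number here means a weaker inhibitor, a lower number a stronger inhibitor. Compound 1, `COc1ccc2occ(C(=O)NC3CCN(Cc4ccccc4)CC3)c(=O)c2c1`, gives 46300 nM in this assay. Compound 2, `COc1ccc2c(=O)c(C(=O)NC3CCN(Cc4ccccc4)CC3)coc2c1`, gives 28600 nM in this assay. Compound 3, `O=C(NCCC1CCN(Cc2ccccc2)CC1)c1coc2ccccc2c1=O`, gives 35300 nM in this assay. Among these three numbers compound 3 stands second highest; its nearest neighbour is compound 2 and its furthest is compound 1, and both gaps fall within the usual scatter of repeated measurements, so the three compounds cannot be told apart on these data. All three are weak inhibitors.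

Compound 4, `Cc1ccc2occ(C(=O)NCCC3CCN(Cc4ccccc4)CC3)c(=O)c2c1`, has not yet been measured. It differs from compound 3 in a single place: methyl in place of hydrogen on an aromatic carbon. Among the compounds with values here, no pair of measured compounds here differs by a change of this kind, so the step has no direct precedent among the numbers at hand, and the change itself is a small one.

The step from compound 3 to compound 4 in this assay is expected to be small, a 1.2-fold lower number from compound 3 to compound 4 (0.07 log units; within the scatter), with no clear direction beyond the scatter. Compound 4 is therefore estimated at 30000 nM, with a likely range from 10000 nM to 90000 nM.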

Compound 4, half-maximal inhibitory concentration: 52500 nM
Compound 4: middle estimate off by 1.8-fold (0.24 log units), on the low side; the measured number falls inside the stated range.
By their numbers in this assay, from the lowest: compounds 2, 3, 1 and 4 (each within the scatter of the next).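

In this assay, the change of methyl in place of hydrogen on an aromatic carbon gives a 1.5-fold higher number from compound 3 to compound 4 (0.17 log units; within the scatter), the first step among these compounds that isolates a single change at this position. The added carbon, placed meta to a fused ring and para to a fused ring on the six-membered aromatic ring, therefore leaves compound 3 and compound 4 indistinguishable on these data, and it does not lift this weak inhibitor series to a clearly stronger number. Nothing at hand accounts for the reading at this position or tells what the methyl does there.

Going by these compounds, one small group on one compound says little about how this carbon responds more generally, so it remains open whether a chlorine atom, an amine or a carboxylic acid at the same place would move the number beyond the scatter. On these data alone, it is also open whether a longer chain there, such as ethyl or propyl, would read the same as methyl, or whether the step would hold with a different link between the amide and the rest of the molecule.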